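The source may hold more compounds than are shown below. What is called first, only, known or untested is meant among the compounds shown, and "the series" means these compounds.

In a functional assay on DU-145 cells (Homo sapiens) for cytotoxicity, read by MTT assay, with a stated time of 48 h (a higher number here means a weaker inhibitor, a lower number a stronger inhibitor), compound 1 `C#CC1=CC[C@@]2(C)C(=C)CCC[C@]2(C)CC1` gives 387000 nM and compound 2 `C#CC1=CC[C@]2(CC1)C(=C)CC[C@H]2C(C)C` gives 121000 nM. Compound 3 `C=C1CCC[C@]2(C)CCC(c3cn(-c4ccc(C(C)=O)cc4)nn3)=CC[C@@]12C` has the lowest number of the three at 51700 nM, which makes it the strongest inhibitor so far, though still a weak one in absolute terms. Compound 4 `C=C1CCC[C@]2(C)CCC(c3cn(-c4ccc(C)cc4)nn3)=CC[C@@]12C` keeps the core of compound 3 and changes one group: methyl in place of acetyl on an aromatic carbon, para to a large group (methyl in place of acetyl on an aromatic carbon). For the measured compounds named here, no measured pair shows this swap on its own, so the expectation is loose. The estimated step, a 1.2-fold higher number from compound 3 to compound 4 (0.06 log units; within the scatter), is small, probably within the scatter, and leans towards a higher number. For compound 4 the expected value is 60000 nM, with a range from 25000 nM to 130000 nM.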

Compound 4, half-maximal inhibitory concentration: 132000 nM
Compound 4: middle estimate off by 2.2-fold (0.34 log units), on the low side; measured number outside the range, above it.
By their numbers in this assay, from the lowest: compound 3; then compounds 2 and 4 (each within the scatter of the next); then compound 1.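

At this position, on the aromatic carbon para to a large group, the choice of group does count: replacing acetyl with methyl gives a 2.6-fold higher number from compound 3 to compound 4 (0.41 log units; beyond the scatter), a weaker inhibitor by a margin beyond the usual scatter. For the compounds shown here, this is the first pair in the set that differs in one place only, so this step can be tied to that single swap. No measurement at hand explains why the number rises. Still open, as far as these compounds go, is how an amine or a carboxylic acid at this place would compare with acetyl and methyl. Also open, from the compounds shown here alone, is whether the same swap gives a similar step on a different core.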